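The source may hold more compounds than are shown below. What is called first, only, known or untested is meant among the compounds shown, and "the series" means these compounds.

The series shares one core, a secondary amide carrying an isopropyl group and a benzyl arm whose phenol oxygen holds a six-carbon chain ending in an acid or its ethyl ester; the para position of the benzoyl ring carries a varying aromatic group. Compound 1 `CC(C)N(Cc1cccc(OCCCCCC(=O)O)c1)C(=O)c1ccc(-c2cccc3ccccc23)cc1` bears a naphthalen-1-yl group and the free acid. In an ADME assay on HepG2 cells (Homo sapiens) for cytotoxicity, read by CellTiter-Glo and resazurin assay, with a stated time of 72 h (on this read-out lower numbers stand for an effect already at smaller amounts and higher numbers for an effect only at larger amounts of compound), compound 1 gives only a limit of > 26000 nM. Compound 2 `CC(C)N(Cc1cccc(OCCCCCC(=O)O)c1)C(=O)c1ccc(-c2cccc(OCc3ccccc3)c2)cc1` carries a benzyloxyphenyl group instead, again with the free acid. In this assay compound 2 likewise reaches only the limit of > 26000 nM. Compound 3 `CCOC(=O)CCCCCOc1cccc(CN(C(=O)c2ccc(-c3cccc4ccccc34)cc2)C(C)C)c1` is the ethyl ester of compound 1. In this assay compound 3 also stops at a limit of > 26000 nM. The step that the two limits leave unreadable from compound 1 to compound 3 therefore cannot be read, because of the limit of > 26000 nM in this assay, at which 3 of the 3 values shown sit. Compound 3 thus stands at the same limit as both other measured compounds, and no ordering among them can be drawn.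

Compound 4 `CCOC(=O)CCCCCOc1cccc(CN(C(=O)c2ccc(-c3ccc(C(C)=O)s3)cc2)C(C)C)c1` differs from compound 3 in one place: 5-acetylthiophen-2-yl in place of naphthalen-1-yl on an aromatic carbon. Going by the values given here, no measured step covers an exchange of this aromatic group, and the only measured step, a step that the two limits leave unreadable from compound 1 to compound 3, yields no readable size. With every value in the series at the limit, the expectation for compound 4 is that the step that the limit leaves unreadable from compound 3 to compound 4 stays within the scatter and the assay again reports no number. Compound 4 is therefore estimated at 30000 nM, within 14000 nM to 80000 nM.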

Compound 4, half-maximal effective concentration: > 26000 nM
Compound 4 was reported as a limit; the forecaster's own chance of this, stated with the estimate: 80%; the middle value is on the limit's open side.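

In this assay compound 4 also gives only a limit, > 26000 nM. The step from compound 3 to compound 4 therefore cannot be read, because both compounds stop at the same point: the limit of > 26000 nM in this assay, at which 4 of the 4 values shown sit. The compounds shown leave open how they rank against one another, and whether the aromatic group or the ester changes this read-out at all.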